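Trimming a Large Side Group to a Methyl

A few compounds are considered here, and "the series" means these few. Any claim that something is new, unique, unknown or untested is made for them only; others in the source may bear on it.

Measured so far:
In an assay on isolated protein for inhibition of 2-Hydroxyacid oxidase 1 (Homo sapiens), with stated times of 30 min and 15 min (a higher number here means a weaker inhibitor, a lower number a stronger inhibitor), compound 1 `CC(C)c1csc(-c2cccc(CNc3ccc4[nH]nc(C(=O)O)c4c3)c2O)n1` gives 65 nM.
In this assay compound 2 `CC(C)c1noc(-c2cccc(CNc3ccc4[nH]nc(C(=O)O)c4c3)c2O)n1` gives 47 nM.

The two numbers sit within the scatter of each other, as the step of a 1.4-fold lower number from compound 1 to compound 2 (0.14 log units; within the scatter) shows, so neither compound can be called the stronger inhibitor. Compound 3 `Cc1cccc(CNc2ccc3[nH]nc(C(=O)O)c3c2)c1O` has not been measured. It differs from compound 2 by methyl in place of 3-isopropyl-1,2,4-oxadiazol-5-yl on an aromatic carbon. Among the compounds with values here, the one measured step exchanges one five-membered ring for another and does not speak to removing the ring entirely; no measured step covers this change. Compound 3 is expected to give 500 nM in this assay, with a range from 120 nM to 3000 nM. This estimate means a step of an 11-fold higher number from compound 2 to compound 3 (1.03 log units; beyond the scatter) toward weaker inhibition.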

Compound 3, half-maximal inhibitory concentration: 17000 nM
For compound 3 the middle estimate is 34-fold (1.53 log units) below the measured one, outside the stated range (above it).
By their numbers in this assay, from the lowest: compounds 2 and 1 (each within the scatter of the next); then compound 3.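

Compound 1 and compound 2 carry different rings at this position, yet their values lie within the scatter of each other; replacing either group with a methyl has a far larger effect in this assay: a 360-fold higher number from compound 2 to compound 3 (2.56 log units; beyond the scatter) and a 260-fold higher number from compound 1 to compound 3 (2.42 log units; beyond the scatter). Among these compounds, then, strong inhibition goes with a large ring-bearing group on this carbon, ortho to a hydroxy group, and not with a methyl. No evidence is available to explain the loss. The compounds shown leave open which part of the large group matters. An isopropyl group alone, or an unsubstituted 1,2,4-oxadiazol-5-yl ring, could begin to separate the contributions of the chain and the ring.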